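Swapping Phenyl for Hydroxymethyl on the Ether Chain

The compounds below may be only part of what the source reports. "The series", "measured", "known", "first", "only" and "open" are said of these compounds alone.

In a functional assay on SH-SY5Y cells (Homo sapiens) for antagonist activity, read by cAMP accumulation (a lower number here means a less potent compound, a higher number a more potent compound, by a factor of ten per unit of this negative logarithm), compound 1 `CCOc1ccc(Cc2ccc(NC3=NCCN3)cc2)cc1` gives 8.2, compound 2 `CCCOc1ccc(Cc2ccc(NC3=NCCN3)cc2)cc1` gives 8.8, and compound 3 `c1ccc(COc2ccc(Cc3ccc(NC4=NCCN4)cc3)cc2)cc1` gives 7.7, the lowest of the three. Compound 4 `OCCOc1ccc(Cc2ccc(NC3=NCCN3)cc2)cc1` has hydroxymethyl in place of phenyl on a saturated chain carbon bound to an oxygen on an aromatic ring. For the measured compounds named here, two measured steps bear on this change, each putting phenyl in place of a small chain group: a number 0.50 log units lower from compound 1 to compound 3 (beyond the scatter), and a number 1.10 log units lower from compound 2 to compound 3 (beyond the scatter). Reversing that swap might suggest a gain, but no measured compound carries hydroxymethyl, so the direction stays uncertain. The expected change is a number 0.10 log units higher from compound 3 to compound 4 (within the scatter), which is not beyond the scatter. Compound 4 is estimated at 7.8, with an expected range of 7 to 8.6.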

Compound 4, negative logarithm of the antagonist equilibrium constant: 8
Compound 4: the middle estimate sits 0.20 log units below what was measured; the measured number falls inside the stated range.
By their numbers in this assay, from the lowest: compounds 3, 4 and 1 (each within the scatter of the next, the first and the last beyond it); then compound 2.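

In this assay, hydroxy on the saturated chain carbon two bonds along the chain from an oxygen on an aromatic ring does not behave like methyl there, with a number 0.80 log units lower from compound 2 to compound 4 (beyond the scatter) beyond the scatter. Against hydrogen on that carbon the result is a number 0.20 log units lower from compound 1 to compound 4 (within the scatter) and, against phenyl, a number 0.30 log units higher from compound 3 to compound 4 (within the scatter), so neither change separates these pairs. No measurement here explains these steps. As far as these compounds go, whether an amine or a carboxylic acid in place of the hydroxy group, or a longer chain ending in hydroxy, would reach the value of compound 2 stays open.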